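The source may hold more compounds than are shown below. What is called first, only, known or untested is meant among the compounds shown, and "the series" means these compounds.

Working notes on the series. The shared core of compound 1 `O=S(=O)(Nc1ccc(-c2nc3ccccc3o2)cc1)c1ccccc1C(F)(F)F` is carried unchanged through compound 2 `COc1ccc(Cl)cc1S(=O)(=O)Nc1ccc(-c2nc3ccccc3o2)cc1` and compound 3 `Cc1cccc(S(=O)(=O)Nc2ccc(-c3nc4ccccc4o3)cc2)c1`; the three differ only in the aryl ring on the sulfonyl sulfur. In an assay on isolated protein for inhibition of malate dehydrogenase, mitochondrial (Sus scrofa), with stated times of 45 min and 30 min (on this read-out lower numbers stand for stronger inhibition and higher numbers for weaker inhibition), compound 1 gives > 63000 nM, which is a limit of the assay and not a number. Compound 2 gives > 63000 nM, again a limit. Compound 3 gives > 63000 nM, also a limit. Among the compounds with values here, compound 3 therefore stands nowhere on a scale: all three values shown sit at the same limit (the limit of > 63000 nM in this assay, at which 3 of the 3 values shown sit), and the one single-point step recorded, a step that the two limits leave unreadable from compound 2 to compound 3, is unreadable from the two limits.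

Compound 4 `O=S(=O)(Nc1ccc(-c2nc3ccccc3o2)cc1)c1cccc(O)c1` is the next single change, (hydroxy in place of methyl on an aromatic carbon). Within the data shown here, no measured step bears readably on it; the only comparable step, a step that the two limits leave unreadable from compound 2 to compound 3, shows nothing beyond two limits. On this basis no step beyond the scatter can be expected in this assay, and the most likely outcome is a further limit. The step from compound 3 to compound 4 is estimated at a step that the limit leaves unreadable from compound 3 to compound 4, that is, no readable change. Compound 4 is expected to give about 80000 nM, within 20000 nM to 300000 nM, most probably reported as a limit.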

Compound 4, half-maximal inhibitory concentration: > 63000 nM
Compound 4: only a limit was reported; the forecaster's own chance of this, stated with the estimate: 80%; the middle value lies beyond the limit too.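

Compound 4 gives > 63000 nM in this assay, again a limit of the assay and not a number. No new step can be read from compound 3 to compound 4 or from compound 2 to compound 4, and the series stays at a single limit: the limit of > 63000 nM in this assay, at which 4 of the 4 values shown sit.

The compounds shown leave open whether any aryl ring on the sulfonyl sulfur of the shared core gives a value short of that limit.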